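This account rests on a few compounds, and the source may have more. Where it says the series, first, only, none or still open, it means among the compounds named here.

Working notes on the propyl and tert-butyl ureas.

Of the compounds shown here, two carry numbers so far. Compound 1 `CCCc1ccc(NC(=O)N[C@@H](C)c2ccccc2)cc1` in an ADME assay on the whole organism with Oryza sativa as the target, tested at 10 uM (on this read-out higher numbers stand for a weaker effect at the one concentration tested and lower numbers for a stronger effect), gives 73%. Compound 2 `C[C@@H](NC(=O)Nc1ccc(C(C)(C)C)cc1)c1ccccc1` in this assay gives 53%. Compound 2 therefore holds the lower of the two numbers, and its nearest neighbour, compound 1, sits higher by a margin that exceeds the scatter.

Compound 3 `C[C@H](NC(=O)Nc1ccc(C(C)(C)C)cc1)c1ccccc1` is not yet measured. It relates to compound 2 as follows: the two compounds have the same atoms and bonds and differ only in configuration as drawn: 1 of 1 stereo elements differ; a stereocentre at a saturated chain carbon is drawn R in compound 2 and S in compound 3. Within the data shown here, nothing so far shows how a change at that stereocentre alone moves the read-out, so no step size can be taken from the measured pairs.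

Expectation: with no stereo comparison available, the step of a number 4 percentage points higher from compound 2 to compound 3 (within the scatter) is estimated as none beyond the scatter, though the range is kept wide. Compound 3 is therefore expected to give about 57%, between 35% and 82%.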

Compound 3, a percentage reported as activity, at one concentration (the size of the read-out at that concentration, not a potency): 64%
The estimate for compound 3 lay 7 percentage points below the measured number; the range from low to high includes it.
By their numbers in this assay, from the lowest: compound 2; then compounds 3 and 1 (each within the scatter of the next).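

In this assay, changing the drawn stereocentre at the saturated chain carbon from R to S gives a number 11 percentage points higher from compound 2 to compound 3 (beyond the scatter), the first sign that configuration at this carbon alone can move the read-out. The step can be assigned to configuration and to no other structural change because of a single point: the fact that compounds 2 and 3 differ only in the configuration as drawn

With the configuration of compound 3 held, tert-butyl in place of propyl on an aromatic carbon gives a number 9 percentage points lower from compound 1 to compound 3 (within the scatter), so in this configuration the two groups cannot be told apart on this read-out.

Open, on these data alone, is whether the configuration step carries over when propyl replaces tert-butyl. Also open, as far as these compounds go, is how a methoxy group, a carboxylic acid or a longer chain on that aromatic carbon would read in either configuration.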